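The source may report more compounds than this note shows. Statements on the series, on what has been measured and on what is new or still open speak of the compounds shown alone.

Compound 1 `CCCOC(=O)C1=C(C)NC(=O)NC1c1ccoc1` gives 1190 nM in an assay on membranes from HEK293 cells for displacement of a labelled ligand from adenosine receptor A2b (Homo sapiens), read by scintillation counting, with a stated time of 30 min; on this read-out higher numbers stand for weaker inhibition and lower numbers for stronger inhibition.
Compound 2 `CC1=C(C(=O)OC2CCCC2)C(c2ccco2)NC(=O)N1` gives 577 nM.
Compound 3 `CCC(C)OC(=O)C1=C(C)NC(=O)NC1c1ccoc1` gives 201 nM.

Compound 3 stands lowest of the three, meaning strongest binding; its gaps to compound 2 and to compound 1 both lie beyond the scatter. Compound 4 `CC1=C(C(=O)OC2CCCC2)C(c2ccoc2)NC(=O)N1` differs from compound 3 by cyclopentyl in place of sec-butyl on an oxygen next to a carbonyl group. Within the data shown here, the only single-change step measured so far, a 5.9-fold lower number from compound 1 to compound 3 (0.77 log units; beyond the scatter), enlarged the group on that same ester oxygen and gave a modest gain. Among the measured compounds shown here, no measured step swaps sec-butyl for cyclopentyl; compound 2 carries cyclopentyl but differs from compound 3 in a second place as well, so only its value can be noted. A similarly sized group is therefore expected to give a change of a 1.5-fold higher number from compound 3 to compound 4 (0.17 log units; within the scatter), likely within the scatter. Compound 4 is estimated at 300 nM, between 100 nM and 900 nM.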

Compound 4, inhibition constant: 1010 nM
Estimate against measurement, compound 4: 3.4-fold (0.53 log units) below, and the stated range ends below it.
By their numbers in this assay, from the lowest: compound 3; then compounds 2, 4 and 1 (each within the scatter of the next, the first and the last beyond it).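

Cyclopentyl does not keep the gain on this ester oxygen: replacing sec-butyl with it weakens binding (a 5.0-fold higher number from compound 3 to compound 4 (0.70 log units; beyond the scatter)). Cyclopentyl also gives no gain over propyl, since that pair stays within the scatter (a 1.2-fold lower number from compound 1 to compound 4 (0.07 log units; within the scatter)), so a larger group here does not by itself bring stronger binding. With cyclopentyl on the ester, furan-3-yl and furan-2-yl cannot be told apart (a 1.8-fold higher number from compound 2 to compound 4 (0.24 log units; within the scatter)).

As far as these compounds go, whether an isopropyl or a cyclobutyl ester would read like sec-butyl or like cyclopentyl remains open. No available data explain why sec-butyl and cyclopentyl differ.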